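The source may hold more compounds than are shown below. What is called first, only, known or untested is meant among the compounds shown, and "the series" means these compounds.

Measured in an ADME assay on the whole organism (strain CD-1) for pharmacokinetics, with Mus musculus as the target, at a dose of 3 mg/kg by the intravenous route; on this read-out higher numbers stand for fast clearance and lower numbers for slow clearance:
- Compound 1 `C[C@H](CCCOc1ccccc1CN(C)C(=O)c1ccc(-c2ccco2)cc1)CC(=O)O`: 0.3 mL/min/kg
- Compound 2 `C/C(=C\CCCOc1ccccc1CN(C)C(=O)c1ccc(-c2ccco2)cc1)C(=O)O`: 4 mL/min/kg
- Compound 3 `CC(CCOc1ccccc1CN(C)C(=O)c1ccc(-c2ccco2)cc1)CCC(=O)O`: 4 mL/min/kg

Compound 3, at 4 mL/min/kg, shares the highest number of the three with compound 2, and the gap to compound 1 is wide: a 13-fold higher number from compound 1 to compound 3 (1.12 log units; beyond the scatter). Compound 4 `C/C(=C\COc1ccccc1CN(C)C(=O)c1ccc(-c2ccco2)cc1)CCC(=O)O` keeps the core and turns the saturated chain into an unsaturated one: 4-carboxy-2-methylbut-1-en-1-yl in place of 4-carboxy-2-methylbutyl on a saturated chain carbon bound to an oxygen on an aromatic ring. The closest guide is another exchange of an unsaturated chain for a saturated one, which gave no change at the digits printed from compound 2 to compound 3 (within the scatter). However, that pair also differs in the chain's layout, and the other step from compound 1 is also large: a 13-fold higher number from compound 1 to compound 2 (1.12 log units; beyond the scatter). A larger move therefore remains possible, but none beyond the scatter is expected in this assay. The expected step is a 1.3-fold higher number from compound 3 to compound 4 (0.10 log units; within the scatter). Compound 4 is estimated at 5 mL/min/kg, within a range of 1.5 mL/min/kg to 14 mL/min/kg.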

Compound 4, clearance: 15 mL/min/kg
Estimate against measurement, compound 4: 3.0-fold (0.48 log units) below; measured number outside the range, above it.
By their numbers in this assay, from the lowest: compound 1; then compounds 2 and 3 (each within the scatter of the next); then compound 4.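

In this assay, the change from 4-carboxy-2-methylbutyl to 4-carboxy-2-methylbut-1-en-1-yl gives a 3.8-fold higher number from compound 3 to compound 4 (0.57 log units; beyond the scatter) and shows that a double bond in this chain can move clearance beyond the scatter. Compound 2 also carries a double bond, yet a 3.8-fold higher number from compound 2 to compound 4 (0.57 log units; beyond the scatter) separates it from the new compound, so chain layout counts here and not just the presence of a double bond. The step of a 50-fold higher number from compound 1 to compound 4 (1.70 log units; beyond the scatter) is the widest span in this set. Still open, from the compounds shown here alone, is how clearance would respond to a tetrazole in place of the carboxylic acid. Nothing shown here gives a measured reason for the rise.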